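A few compounds are considered here, and "the series" means these few. Any claim that something is new, unique, unknown or untested is made for them only; others in the source may bear on it.

In a functional assay on MDA-MB-361 cells (Homo sapiens) for antiproliferative activity, read by MTT assay, with a stated time of 72 h (a lower number here means a stronger inhibitor, a higher number a weaker inhibitor), compound 1 `O=C1NN=C(c2ccccc2)/C1=C/Nc1cc(-c2ccco2)[nH]n1` gives 63700 nM and compound 2 `Cc1cc(N/C=C2\C(=O)NN=C2c2ccccc2)n[nH]1` gives 96100 nM. Going by the values given here, the only measured step is a 1.5-fold higher number from compound 1 to compound 2 (0.18 log units; within the scatter), so compound 2 stands level with compound 1 on these two numbers. Compound 3 `O=C1NN=C(c2ccccc2)/C1=C/N[C@@H](CO)C(=O)O` brings a larger structural change: 1-carboxy-2-hydroxyethyl in place of 5-methyl-1H-pyrazol-3-yl on an amine nitrogen. In words, this is 1-carboxy-2-hydroxyethyl in place of 5-methyl-1H-pyrazol-3-yl on an amine nitrogen. The measured step offers only a weak guide, since it placed methyl in place of furan-2-yl on an aromatic carbon and kept the five-membered aromatic ring that compound 3 loses. Among the compounds with values here, no measured compound lacks that ring, so the expectation in this assay is uncertain, and no step beyond the scatter is expected. The estimated change is a 1.2-fold higher number from compound 2 to compound 3 (0.10 log units; within the scatter). For compound 3 the expected value is 120000 nM, with an estimated range of 40000 nM to 350000 nM.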

Compound 3, half-maximal inhibitory concentration: 105000 nM
Compound 3: the middle estimate sits 1.1-fold (0.06 log units) above what was measured; low and high end bracket the measured number.
By their numbers in this assay, from the lowest: compounds 1, 2 and 3 (each within the scatter of the next).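

In this assay, putting 1-carboxy-2-hydroxyethyl in place of 5-methyl-1H-pyrazol-3-yl on the amine nitrogen gives a 1.1-fold higher number from compound 2 to compound 3 (0.04 log units; within the scatter) and so produces no readable change. At this position, then, the five-membered aromatic ring can be exchanged for an open chain with no ring and a defined stereocentre without the number moving beyond the scatter, something the earlier step could not show, as it kept that ring. Nothing available gives a reason for this result. On these data alone, it remains open whether any group on this amine nitrogen can move the number beyond the scatter in either direction. A plain ethyl chain or a benzyl group there would test whether the result holds for groups without the hydroxyl and the carboxyl of compound 3.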